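Hexyl chain for silicon-capped alkyne: what to expect

The source may report more compounds than this note shows. Statements on the series, on what has been measured and on what is new or still open speak of the compounds shown alone.

Compound 1 `CCCCC#Cc1ccc(S(=O)(=O)Nc2cccc(-c3csc(NC(C)=O)n3)c2)cc1` gives < 1% in a functional assay on A-375 cells (Homo sapiens) for antiproliferative activity, read by trypan blue exclusion, with a stated time of 48 h, tested at 10 uM; on this read-out higher numbers stand for a weaker effect at the one concentration tested and lower numbers for a stronger effect; this is a limit of the assay.
Compound 2 `CC(=O)Nc1nc(-c2cccc(NS(=O)(=O)c3ccc(C#CC4CCCCC4)cc3)c2)cs1` gives 1.2% in this assay.
Compound 3 `CC(=O)Nc1nc(-c2cccc(NS(=O)(=O)c3ccc(C#C[Si](C)(C)C)cc3)c2)cs1` gives < 1% in this assay; this too is a limit.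

Compound 3 thus stands at the limit of < 1% in this assay, at which 2 of the 3 values shown sit, not at a number. Compound 4 `CCCCCCc1ccc(S(=O)(=O)Nc2cccc(-c3csc(NC(C)=O)n3)c2)cc1` differs from it by a group of 6 heavy atoms (6 carbon; no ring) in place of a group of 6 heavy atoms (5 carbon, 1 silicon; no ring), on an aromatic carbon. For the measured compounds named here, the steps that bear on it all change the group on the triple-bonded carbon: a number at least 0.2 percentage points higher from compound 1 to compound 2 (that floor lies within the scatter), a number at least 0.2 percentage points lower from compound 2 to compound 3 (that floor lies within the scatter) and a step that the two limits leave unreadable from compound 1 to compound 3. None of them leaves the scatter, so no step beyond the scatter is expected here either. Compound 4 is therefore expected near 1%, between 0.3% and 4%. The expected step of a number no lower from compound 3 to compound 4 (the limit leaves the size open) stays within the scatter, and a limit rather than a number is the likelier report.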

Compound 4, a percentage reported as activity, at one concentration (the size of the read-out at that concentration, not a potency): <= 1%
Compound 4: only a limit was reported; the forecaster's own chance of this, stated with the estimate: 60%; the middle value lies on the limit itself.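

Compound 4 stands at a limit of its own: the limit of <= 1% in this assay, at which 1 of the 4 values shown sits.

For the compounds shown here, the earlier compounds all carried a triple bond at this position, and hexyl shows that the read-out stays this low without one, the one readable step being a number at least 0.2 percentage points lower from compound 2 to compound 4 (that floor lies within the scatter). The other two steps, each between two limits, cannot be read.

On these data alone, whether an amine or a carboxylic acid on this aromatic carbon would raise the read-out clear of the limit stays open. So does any ranking among compound 1, compound 3 and compound 4.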